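The compounds below may be only part of what the source reports. "The series", "measured", "known", "first", "only" and "open" are said of these compounds alone.

Series notes. Compound 1 `COc1ccnc(C[S+]([O-])c2nc3cc(OC(F)F)ccc3[nH]2)c1` is the parent, compound 2 `COc1ccnc(C[S+]([O-])c2nc3cc(OC(F)F)ccc3[nH]2)c1C` its methylated analogue; compound 3 `COc1cnc(C[S+]([O-])c2nc3cc(OC(F)(F)C(F)F)ccc3[nH]2)cc1OC` carries a different core, and the difference between the two cores is not broken down here. In an ADME assay, at pH 5 (on this read-out lower numbers stand for a shorter-lived compound and higher numbers for a longer-lived compound), compound 1 gives 0.8 h, and compound 2 gives 0.17 h. The change methyl in place of hydrogen on an aromatic carbon brought a 4.7-fold lower number from compound 1 to compound 2 (0.67 log units; beyond the scatter). In this assay compound 3 gives 2.9 h. Compound 4 `COc1cnc(C[S+]([O-])c2nc3cc(OC(F)(F)C(F)F)ccc3[nH]2)c(C)c1OC` has not been run in this assay. It carries the same kind of change on the core of compound 3: methyl in place of hydrogen on an aromatic carbon; the place here is also meta to a methoxy group (2 heavy atoms). Within the data shown here, a step of similar size is expected from compound 3 to compound 4 in this assay, a 4.1-fold lower number from compound 3 to compound 4 (0.62 log units; beyond the scatter), because the only measured example of this change gave a 4.7-fold lower number from compound 1 to compound 2 (0.67 log units; beyond the scatter). Compound 4 is therefore estimated at 0.7 h in this assay.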

Compound 4, half-life: 6.8 h
The estimate for compound 4 lay 9.7-fold (0.99 log units) below the measured number; the measured number lies above the stated range.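

Methyl in place of hydrogen on an aromatic carbon brought a 2.3-fold higher number from compound 3 to compound 4 (0.37 log units; beyond the scatter) in this assay. On these two pairs, the change does not carry from one core to the other in either size or direction: the same change on two cores in this assay, a 4.7-fold lower number (0.67 log units; beyond the scatter) from compound 1 to compound 2 and a 2.3-fold higher number (0.37 log units; beyond the scatter) from compound 3 to compound 4, 11-fold (1.04 log units) apart, beyond the scatter of two such steps
Among these compounds, this shows that the step measured on one core is no guide to the step on the other, but not which part of the difference between the cores matters, nor how the change would run on a further core. Which part of that difference separates the two steps remains open. Also open, on these data alone, is whether an ethyl group or a chlorine atom in place of the same hydrogen would follow the methyl step on either core.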